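Trifluoromethoxy on the core: expected step from compound 1

The compounds below may be only part of what the source reports. "The series", "measured", "known", "first", "only" and "open" are said of these compounds alone.

Among the compounds with values here, compound 1 `C[C@@H]1COc2ccccc2[C@H](C)N1C(=O)c1ccc(Cl)cc1` stands highest of the two numbers so far: in a functional assay on CHO cells for antagonist activity at Orexin receptor type 2 (Homo sapiens), read by FLIPR and calcium flux (a higher number here means a weaker inhibitor, a lower number a stronger inhibitor), compound 1 gives 6400 nM. Compound 2 `CSc1ccc2c(c1)[C@H](C)N(C(=O)c1ccc(Cl)cc1)[C@H](C)CO2` gives 6.4 nM in this assay; the step of a 1000-fold lower number from compound 1 to compound 2 (3.00 log units; beyond the scatter) is the only one measured and it bears directly here, as compound 3 `C[C@@H]1COc2ccc(OC(F)(F)F)cc2[C@H](C)N1C(=O)c1ccc(Cl)cc1` also carries a substituent on an aromatic carbon of the core: trifluoromethoxy in place of hydrogen on an aromatic carbon. A large drop is therefore expected, likely somewhat short of that seen for compound 2, so compound 3 is estimated at 30 nM, range 5 nM to 300 nM, a step of a 210-fold lower number from compound 1 to compound 3 (2.33 log units; beyond the scatter) expected.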

Compound 3, half-maximal inhibitory concentration: 140 nM
Estimate against measurement, compound 3: 4.7-fold (0.67 log units) below; the range from low to high includes it.
By their numbers in this assay, from the lowest: compound 2; then compound 3; then compound 1.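

The change a 46-fold lower number from compound 1 to compound 3 (1.66 log units; beyond the scatter) in this assay shows that the large gain at this aromatic carbon is not unique to methylsulfanyl. The choice of group still matters: the change a 22-fold higher number from compound 2 to compound 3 (1.34 log units; beyond the scatter) leaves trifluoromethoxy well short of methylsulfanyl at the same place. Nothing available accounts for this gap between the two groups.

Open, on these data alone, is whether an amine, a carboxylic acid or ethylsulfanyl on this carbon would keep the gain. Also open, as far as these compounds go, is whether substitution on the other aromatic carbons of the shared core gives a comparable step.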